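The source may report more compounds than this note shows. Statements on the series, on what has been measured and on what is new or still open speak of the compounds shown alone.

Measured so far in a functional assay on OVCAR-5 cells (Homo sapiens) for inhibition, read by sulforhodamine B assay, with a stated time of 48 h; on this read-out lower numbers stand for stronger inhibition of growth and higher numbers for weaker inhibition of growth:
compound 1 `COc1ccc(-c2[nH]c3ccccc3c2/C=C(\C#N)S(=O)(=O)c2ccccc2)cc1` — 1900 nM
compound 2 `CC(=O)/C(=C\c1c(-c2ccccc2)[nH]c2ccccc12)S(=O)(=O)c1ccccc1` — 2000 nM
compound 3 `COc1ccc2[nH]c(-c3ccccc3)c(/C=C(\C#N)S(=O)(=O)c3ccccc3)c2c1` — 37300 nM

Compound 3 stands highest of the three numbers in this assay, meaning the weakest growth inhibition of the set. Compound 2 is nearest to it, with a number well below that of compound 3 and beyond the scatter; compound 1 is furthest, also well below and beyond the scatter. Compound 1 and compound 2 lie within the scatter of each other, so no order between them is claimed.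

Compound 4 `N#C/C(=C\c1c(-c2ccccc2)[nH]c2ccccc12)S(=O)(=O)c1ccccc1` differs from compound 3 in one place: hydrogen in place of methoxy on an aromatic carbon. Going by the values given here, no pair of measured compounds shows this change alone, so its size has no measured counterpart. What the series does show is that compound 1 and compound 2, both without a methoxy on the fused six-membered ring of the shared core, sit far below compound 3 in this assay. Compound 4 shares that feature, and its number is expected to move back toward theirs: a large step down, beyond the scatter, estimated as a 15-fold lower number from compound 3 to compound 4 (1.17 log units; beyond the scatter). Compound 4 is therefore estimated at 2500 nM in this assay, with an expected range from 800 nM to 8000 nM.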

Compound 4, concentration for 50% growth inhibition: 13900 nM
Compound 4: the middle estimate sits 5.6-fold (0.75 log units) below what was measured; the measured number lies above the stated range.
By their numbers in this assay, from the lowest: compounds 1 and 2 (each within the scatter of the next); then compound 4; then compound 3.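

In this assay the exchange of methoxy for hydrogen on an aromatic carbon of the fused system of two rings gives a 2.7-fold lower number from compound 3 to compound 4 (0.43 log units; beyond the scatter) and the same exchange at a different aromatic carbon gives a 7.3-fold higher number from compound 1 to compound 4 (0.86 log units; beyond the scatter) in the opposite direction, so among these compounds the direction of this change depends on where the methoxy sits. With the methoxy absent from both compounds, cyano in place of acetyl on the double-bonded chain carbon gives a 7.0-fold higher number from compound 2 to compound 4 (0.84 log units; beyond the scatter) as a separate step of similar size, and so compound 4 is not the best reference point in the series even though it carries neither of these groups. Nothing available here accounts for the direction or size of any of these steps.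

The compounds shown leave open whether an amine or an ethoxy group at the same carbon of the fused system would follow the methoxy or the hydrogen. They also leave open how a carboxylic acid or an amide would compare with acetyl and cyano on the double-bonded chain carbon, and whether the methoxy and acetyl steps would combine in one compound.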